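Removing the methoxy group from compound 1

The source may hold more compounds than are shown below. What is called first, only, known or untested is meant among the compounds shown, and "the series" means these compounds.

Measured in an ADME assay for metabolic stability, in phosphate buffer, at pH 7.3; on this read-out lower numbers stand for a shorter-lived compound and higher numbers for a longer-lived compound:
- compound 1 `COc1ccc2c(c1)COP(=O)(OCC1CCC(n3cnc4c(N)ncnc43)O1)O2`: 23.4 h
- compound 2 `Cc1cc(C)c2c(c1)COP(=O)(OCC1CCC(n3cnc4c(N)ncnc43)O1)O2`: 58.2 h

Of these two numbers, compound 1 holds the lower, and compound 2 lies above it by more than the usual scatter. Within the data shown here, the two compounds differ in more than one place, so no single-change step has been measured yet, and the gap between them does not isolate any one group.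

The next compound is compound 3 `Nc1ncnc2c1ncn2C1CCC(COP2(=O)OCc3ccccc3O2)O1`, which has hydrogen in place of methoxy on an aromatic carbon. Among the measured compounds shown here, with no measured step for this change, the expectation is tentative. Compound 1 at 23.4 h and compound 2 at 58.2 h both carry groups on the aromatic ring, whereas compound 3 has none there. A downward step in this assay is therefore expected, modestly beyond the scatter, towards a shorter-lived compound. The expected change is a 2.3-fold lower number from compound 1 to compound 3 (0.37 log units; beyond the scatter). Compound 3 is estimated at 10 h, with an expected range of 5 h to 20 h.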

Compound 3, half-life: 17 h
Compound 3: middle estimate off by 1.7-fold (0.23 log units), on the low side; low and high end bracket the measured number.
By their numbers in this assay, from the lowest: compounds 3 and 1 (each within the scatter of the next); then compound 2.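

In this assay the series now has its first single-change step, a 1.4-fold lower number from compound 1 to compound 3 (0.14 log units; within the scatter), and this step lies within the scatter. On this aromatic carbon of the six-membered aromatic ring, replacing methoxy with hydrogen removes 2 heavy atoms and 1 hydrogen-bond acceptor, yet it does not separate compound 1 from compound 3 on this read-out. Compound 3 also gives the series a form with no group on this ring, a reference point for reading other single changes made there.

From the compounds shown here alone, whether another group at this position, such as an amine, a carboxylic acid or a longer alkoxy chain, would give a step beyond the scatter remains open. Among these compounds, also unresolved is what each methyl group on the ring of compound 2 contributes, as no single-change step isolates either one. No supporting data are available to explain the result of this change.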